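Bromo for methyl in compound 3: an expected step

The compounds below may be only part of what the source reports. "The series", "measured", "known", "first", "only" and "open" are said of these compounds alone.

Measured in a functional assay on thoracic aorta (Rattus norvegicus, strain Wistar), with a stated time of 15 min; on this read-out higher numbers stand for an effect only at larger amounts of compound and lower numbers for an effect already at smaller amounts:
Compound 1 `COc1ccc(Br)cc1C(C)NC(=O)NS(=O)(=O)c1ccc(C)cc1`: > 300000 nM (a limit of the assay, not a number)
Compound 2 `Cc1ccc(S(=O)(=O)N(C)C(=O)NC(C)c2cc(Br)ccc2OCc2ccccc2)cc1`: 67100 nM
Compound 3 `Cc1ccc(S(=O)(=O)NC(=O)NC(C)c2cc(C)ccc2OCc2ccccc2)cc1`: 91900 nM

Compound 1 gives only a limit, > 300000 nM, as the limit of > 300000 nM in this assay, at which 1 of the 3 values shown sits, records. That leaves two numbers in this assay, and compound 3 at 91900 nM lies within the usual scatter of compound 2 at 67100 nM.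

The next compound to be tested is compound 4 `Cc1ccc(S(=O)(=O)NC(=O)NC(C)c2cc(Br)ccc2OCc2ccccc2)cc1`. It replaces methyl with bromo on an aromatic carbon, meta to a large group and para to a benzyloxy group: bromo in place of methyl on an aromatic carbon.

Among the measured compounds shown here, no measured pair shows this swap on its own, so the expectation rests on the two numbers alone. No shift beyond the scatter is expected in this assay, at most a slight drift toward a lower number. The estimated change is a 1.4-fold lower number from compound 3 to compound 4 (0.15 log units; within the scatter). For compound 4 the expected value is 65000 nM, with an estimated range from 22000 nM to 190000 nM.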

Compound 4, half-maximal effective concentration: 138000 nM
Estimate against measurement, compound 4: 2.1-fold (0.33 log units) below; the measured number falls inside the stated range.
By their numbers in this assay, from the lowest: compounds 2, 3 and 4 (each within the scatter of the next, the first and the last beyond it). At a limit, above all of these: compound 1.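

In this assay, among the compounds shown here, bromo in place of methyl on an aromatic carbon para to a benzyloxy group gives a 1.5-fold higher number from compound 3 to compound 4 (0.18 log units; within the scatter), so this swap, which no earlier pair showed on its own, stays within the scatter at this position. Hydrogen in place of methyl on the amide-type nitrogen gives a 2.1-fold higher number from compound 2 to compound 4 (0.31 log units; beyond the scatter), the only step between two numbers here that lies beyond the scatter. Phenyl in place of hydrogen on a saturated chain carbon bound to an oxygen on an aromatic ring gives an at least 2.1-fold lower number from compound 1 to compound 4 (0.33 log units; beyond the scatter), a step read against a limit and not a number for compound 1: the limit of > 300000 nM in this assay, at which 1 of the 4 values shown sits.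

The compounds shown leave open whether other groups on this aromatic carbon, such as chloro, methoxy or nitrile, would also stay within the scatter of compound 4. They also leave open what a longer chain in place of the methyl on the amide-type nitrogen would do.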